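Ethyl for methyl on the amide nitrogen of the shared core

The source may report more compounds than this note shows. Statements on the series, on what has been measured and on what is new or still open speak of the compounds shown alone.

Compound 1 `CS(=O)(=O)Nc1ccc2c(c1)S(=O)(=O)N=C(C1=C(O)C3CCCC3N(Cc3ccc(F)cn3)C1=O)N2`: in an ADME assay on Huh-7 cells (Homo sapiens) for cytotoxicity, with a stated time of 72 h (a lower number here means that less compound is tolerated, a higher number that more compound is tolerated), compound 1 gives > 33000 nM, which is a limit of the assay.
Compound 2 `CS(=O)(=O)Nc1ccc2c(c1)S(=O)(=O)N=C(C1=C(O)C3CCCC3N(CC3CCC3)C1=O)N2`: in this assay compound 2 gives > 33000 nM, again a limit of the assay.
Compound 3 `CN1C(=O)C(C2=NS(=O)(=O)c3cc(NS(C)(=O)=O)ccc3N2)=C(O)C2CCCC21`: in this assay compound 3 gives "not determined" (no result reported), so no result was reported.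

Compound 3 therefore stands nowhere on the numbers shown: the only two values available in this assay are limits, and neither belongs to compound 3. Compound 4 `CCN1C(=O)C(C2=NS(=O)(=O)c3cc(NS(C)(=O)=O)ccc3N2)=C(O)C2CCCC21` differs from compound 3 by methyl in place of hydrogen on a saturated chain carbon bound to an amide-type nitrogen in a ring. Among the compounds with values here, the one measured step, a step that the two limits leave unreadable from compound 1 to compound 2, also changes the group on a saturated chain carbon bound to an amide-type nitrogen in a ring, but its size cannot be read, since both of its ends sit at the limit of > 33000 nM in this assay, at which 2 of the 3 values shown sit. Within the data shown here, two of the three values shown sit at that limit, and nothing among the measured compounds indicates a move away from it for so small a change. Compound 4 is therefore expected to show no cytotoxicity beyond the scatter within the tested range of this assay, with an estimated value of 40000 nM (20000 nM to 100000 nM), most likely reported once more only as a limit.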

Compound 4, half-maximal cytotoxic concentration: > 33000 nM
Compound 4: no number, only a limit (the forecaster's own chance of this, stated with the estimate: 85%); the middle value lies beyond the limit too.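

In this assay compound 4 gives only a limit, as compound 1 and compound 2 do, so neither the step from compound 1 to compound 4 nor that from compound 2 to compound 4 can be read: the limit of > 33000 nM in this assay, at which 3 of the 4 values shown sit. The compounds shown leave open whether the methyl, cyclobutyl and 5-fluoropyridin-2-yl groups differ at all in this assay, and where compound 3 stands.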